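The source may report more compounds than this note shows. Statements on the series, on what has been measured and on what is new or still open speak of the compounds shown alone.

Measured so far:
- compound 1 `COc1cc(C(=O)/C=C\Nc2ccc(-c3nc4cc(OC)c(OC)c(OC)c4s3)cc2)c(Br)c(OC)c1OC` — 13600 nM
- compound 2 `COc1ccc2nc(-c3ccc(N/C=C\C(=O)c4ccc(OC)c(O)c4)c(C)c3)sc2c1` — 18000 nM
- compound 3 `COc1cc(OC)c2sc(-c3ccc(N/C=C\C(=O)c4ccc(OC)c(O)c4)cc3)nc2c1` — 10600 nM

In a functional assay on A549 cells (Homo sapiens) for antiproliferative activity, read by sulforhodamine B assay, with a stated time of 48 h (on this read-out higher numbers stand for weaker inhibition and lower numbers for stronger inhibition), compound 1 gives 13600 nM, the second highest of the three numbers; compound 3 and compound 2 sit on either side of it, both within the scatter, so the three measured compounds cannot be told apart on this read-out. Among the compounds with values here, no pair of measured compounds differs in only one place, so no measured step is available. Compound 4 `COc1cc(OC)c2sc(-c3ccc(N/C=C\C(=O)c4cc(OC)c(OC)c(OC)c4Br)cc3)nc2c1` differs from compound 1 by hydrogen in place of methoxy on an aromatic carbon. Nothing in the measured set speaks to this change, and all three numbers lie close together, so the expected step from compound 1 to compound 4 is none beyond the scatter: a 1.0-fold lower number from compound 1 to compound 4 (0.02 log units; within the scatter) is expected. Compound 4 is estimated at 13000 nM, with a range from 5000 nM to 35000 nM.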

Compound 4, half-maximal inhibitory concentration: 12000 nM
Compound 4: the middle estimate sits 1.1-fold (0.03 log units) above what was measured; the range from low to high includes it.
By their numbers in this assay, from the lowest: compounds 3, 4, 1 and 2 (each within the scatter of the next).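

Within the data shown here, this is the first measured step: in this assay, hydrogen in place of methoxy on the aromatic carbon ortho to two methoxy groups gives a 1.1-fold lower number from compound 1 to compound 4 (0.05 log units; within the scatter) and so shows no readable dependence on this methoxy group. At this position, the read-out tolerates the loss of these 2 heavy atoms. No evidence at hand bears on the reason for this result. Going by these compounds, whether an amine or a carboxylic acid at this carbon would give a step beyond the scatter remains open, as does the outcome with a longer alkoxy chain.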